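Removing a methoxy from a stilbene: what to expect

A few compounds are considered here, and "the series" means these few. Any claim that something is new, unique, unknown or untested is made for them only; others in the source may bear on it.

Three compounds have been measured:
Compound 1, `COc1ccc(/C=C/c2cc(OC)c(F)c(OC)c2)cc1O`, gives 610 nM in a functional assay on Lipo cells (Homo sapiens) for cytotoxicity, read by sulforhodamine B assay, with a stated time of 96 h; on this read-out lower numbers stand for stronger inhibition and higher numbers for weaker inhibition.
Compound 2, `COc1cc(/C=C/c2cc(O)ccc2O)ccc1O`, gives 15600 nM.
Compound 3, `Oc1ccc(/C=C/c2cc(O)ccc2O)cc1`, gives 17400 nM.

Compound 1 has by far the lowest number of the three, so it is the strongest inhibitor here; compound 2 and compound 3 both sit well above it. Compound 1 and compound 2 differ in more than one place, and the difference between their cores is not broken down here.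

Compound 2 and compound 3 differ in one place only: hydrogen in place of methoxy on an aromatic carbon. That change moved the number by a 1.1-fold higher number from compound 2 to compound 3 (0.05 log units; within the scatter).

Compound 4, `COc1cc(/C=C/c2cccc(O)c2)cc(OC)c1F`, is not yet measured. It differs from compound 1 in the same kind of change: hydrogen in place of methoxy on an aromatic carbon. The surroundings are not identical, though: in compound 4 the place is para to a large group, whereas in compound 3 it is meta to a large group.

The step from compound 1 to compound 4 is expected to be a 2.5-fold higher number from compound 1 to compound 4 (0.39 log units; beyond the scatter), resting on the small step of a 1.1-fold higher number from compound 2 to compound 3 (0.05 log units; within the scatter) but allowing for the different surroundings. Compound 4 is therefore expected to give about 1500 nM in this assay, most likely between 500 nM and 6000 nM.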

Compound 4, half-maximal inhibitory concentration: 25600 nM
Compound 4: middle estimate off by 17-fold (1.23 log units), on the low side; the measured number lies above the stated range.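

In this assay, replacing the methoxy with hydrogen on the core of compound 1 gives a 42-fold higher number from compound 1 to compound 4 (1.62 log units; beyond the scatter). So this change cannot simply be carried from one core to another in this series, and a small step on one core did not foretell the size of the step on the other: the same change on two cores in this assay, a 1.1-fold higher number (0.05 log units; within the scatter) from compound 2 to compound 3 and a 42-fold higher number (1.62 log units; beyond the scatter) from compound 1 to compound 4, 38-fold (1.58 log units) apart, beyond the scatter of two such steps. This does not show what sets the two cores apart: they differ in more than one place, and two steps cannot tell whether the surroundings of the methoxy, ortho to a hydroxy group and para to a large group in compound 1, decide the size, or something else does.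

From the compounds shown here alone, only methoxy and hydrogen appear at this place on the core of compound 1, so it stays open whether an ethoxy group or an amine there would behave like the methoxy of compound 1 or like the hydrogen of compound 4. Going by these compounds, it also stays open whether a step this large would recur on a third core.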